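One Carbon Further Out: From Compound 3 to Compound 4

The source may report more compounds than this note shows. Statements on the series, on what has been measured and on what is new or still open speak of the compounds shown alone.

Measured so far in an assay on isolated protein for inhibition of protein kinase C delta type (Homo sapiens), read by TR-FRET, with a stated time of 2 h; a lower number here means a stronger inhibitor, a higher number a weaker inhibitor:
Compound 1 `N#Cc1cnc(NCc2cnccc2C(F)(F)F)cc1N[C@H]1C[C@@H](O)C1` gives > 10000 nM, which is a limit of the assay rather than a number.
Compound 2 `N#Cc1cnc(NCc2cnccc2C(F)(F)F)cc1NC[C@H]1C[C@@H](O)C1` gives 4200 nM.
Compound 3 `N#Cc1cnc(NCc2cnccc2C(F)(F)F)cc1N[C@H]1CC[C@H](O)CC1` gives 6500 nM.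

Compound 3 holds the highest of the two numbers actually measured, but its nearest neighbour is compound 2, with a 1.5-fold higher number from compound 2 to compound 3 (0.19 log units; within the scatter), so the two cannot be told apart. Compound 4 `N#Cc1cnc(NCc2cnccc2C(F)(F)F)cc1NC[C@H]1CC[C@@H](O)CC1` differs from compound 3 in one place: (4-hydroxycyclohexyl)methyl in place of 4-hydroxycyclohexyl on a nitrogen on an aromatic ring. The closest measured step is the same change on the 3-hydroxycyclobutyl ring, an at least 2.3-fold lower number from compound 1 to compound 2 (0.37 log units; beyond the scatter); its full size is uncertain because compound 1 sits at the limit of > 10000 nM in this assay, at which 1 of the 3 values shown sits. A modest lowering in this assay is therefore expected, a 2.2-fold lower number from compound 3 to compound 4 (0.34 log units; beyond the scatter). Compound 4 is estimated at 3000 nM, within a range from 1200 nM to 8000 nM.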

Compound 4, half-maximal inhibitory concentration: 500 nM
Beside the measured number, compound 4's estimate is 6.0-fold (0.78 log units) above it; the whole stated range lies above it.
By their numbers in this assay, from the lowest: compound 4; then compounds 2 and 3 (each within the scatter of the next). At a limit, above all of these: compound 1.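

In this assay, one added carbon between the nitrogen and the 4-hydroxycyclohexyl ring has a large effect, with a 13-fold lower number from compound 3 to compound 4 (1.11 log units; beyond the scatter). With that carbon in place, the larger ring also gives the stronger inhibitor, with an 8.4-fold lower number from compound 2 to compound 4 (0.92 log units; beyond the scatter). Against the 3-hydroxycyclobutyl compound without the added carbon, the result is an at least 20-fold lower number from compound 1 to compound 4 (1.30 log units; beyond the scatter), but that size is only a floor: the limit of > 10000 nM in this assay, at which 1 of the 4 values shown sits.

Going by these compounds, it remains open whether a longer chain in place of the single carbon would lower the number further. It is also unknown whether an amine could replace the hydroxy group on the ring without losing this gain.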